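This account rests on a few compounds, and the source may have more. Where it says the series, first, only, none or still open, it means among the compounds named here.

Working notes on the series. In a physicochemical assay for lipophilicity, at pH 7.4 (a higher number here means a more lipophilic compound, a lower number a more polar compound), compound 1 `O=S(=O)(c1ccc2c(c1)C(O)CC(C1CCOCC1)O2)N1CCCC1c1ccccc1C(F)(F)F` gives 3.41. In this assay compound 3 `Cc1ccc(N(C2CCC2)S(=O)(=O)c2ccc3c(c2)C(O)CC(C2CCOCC2)O3)c(C)c1` gives 3.77. Compound 2 `CCc1ccc(N(CC(C)C)S(=O)(=O)c2ccc3c(c2)C(O)CC(C(C)C2CCOCC2)O3)cc1` gives 5.04 in this assay, the highest of the three numbers: compound 3 stands nearest, lower by a gap beyond the scatter, and compound 1 stands furthest, again beyond the scatter. Compound 4 `CCc1ccc(N(CC(C)C)S(=O)(=O)c2ccc3c(c2)C(O)CC(C2CCOCC2)O3)cc1` has not yet been measured in this assay. It differs from compound 2 in one place: oxan-4-yl in place of 1-(oxan-4-yl)ethyl on a saturated ring carbon. The group that leaves carries 8 heavy atoms, the one that enters 6. With one carbon fewer, the step of a number 0.54 log units lower from compound 2 to compound 4 (beyond the scatter) is expected to run downward and to exceed the scatter, though not by much. Compound 4 is therefore expected to give 4.5 in this assay, with a range from 4.1 to 4.9.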

Compound 4, distribution coefficient: 4.12
Beside the measured number, compound 4's estimate is 0.38 log units above it; low and high end bracket the measured number.
By their numbers in this assay, from the lowest: compound 1; then compound 3; then compound 4; then compound 2.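

Oxan-4-yl in place of 1-(oxan-4-yl)ethyl on a saturated ring carbon, next to the ring oxygen, gives a number 0.92 log units lower from compound 2 to compound 4 (beyond the scatter) in this assay. Within the data shown here, this is the only step here that differs in one place, so it ties a change in the number to this position with the rest of the molecule held constant. No measurement at hand accounts for the size of the step. The compounds shown leave open how a longer chain or an amine at this position would read in this assay. On these data alone, whether the same change gives a similar step alongside the other groups of compound 1 or compound 3 also remains open.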